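Rat clearance expected for compound 4

A few compounds are considered here, and "the series" means these few. Any claim that something is new, unique, unknown or untested is made for them only; others in the source may bear on it.

Measured so far in an in vivo ADME assay on the whole organism (plasma, strain Sprague-Dawley) for pharmacokinetics, with Rattus norvegicus as the target, read by LC-MS; on this read-out lower numbers stand for slow clearance and higher numbers for fast clearance:
Compound 1 `CC(C)(C)c1cc(NC(=O)Nc2ccc(NC(=O)c3ccc(OC4CCNCC4)cn3)cc2)no1` gives 22.1 mL/min/kg
Compound 2 `CC(C)(C)c1cc(NC(=O)Nc2ccc(NC(=O)c3ccc(OC4CCN(C5CC5)CC4)cn3)cc2)no1` gives 12 mL/min/kg
Compound 3 `CCN1CCC(Cc2ccc(C(=O)Nc3ccc(NC(=O)Nc4cc(C(C)(C)C)on4)cc3)nc2)CC1` gives 24 mL/min/kg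

Compound 3 is not separated from the other two compounds. The data show a 1.1-fold higher number from compound 1 to compound 3 (0.04 log units; within the scatter) and also a 2.0-fold higher number from compound 2 to compound 3 (0.30 log units; within the scatter), so its place among the three numbers carries little weight.

Compound 4 `CC(C)N1CCC(Oc2ccc(C(=O)Nc3ccc(NC(=O)Nc4cc(C(C)(C)C)on4)cc3)nc2)CC1` has not yet been measured. It differs from compound 3 in one place: (1-isopropylpiperidin-4-yl)oxy in place of (1-ethylpiperidin-4-yl)methyl on an aromatic carbon, while the shared core stays the same.

Where compound 4 has (1-isopropylpiperidin-4-yl)oxy, compound 2 has (1-cyclopropylpiperidin-4-yl)oxy and gives 12 mL/min/kg as the closest measured match. The step of a 2.0-fold higher number from compound 2 to compound 3 (0.30 log units; within the scatter) is therefore the most relevant, since it is a similar exchange run the other way. The step of a 1.8-fold lower number from compound 1 to compound 2 (0.27 log units; within the scatter) shows what a change on the ring nitrogen has done so far. Among the compounds with values here, no measured step goes beyond the scatter, so no step beyond the scatter is expected here, only a lean toward the value of compound 2.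

The expected change is a 1.6-fold lower number from compound 3 to compound 4 (0.20 log units; within the scatter) in this assay by this reasoning. For compound 4 the estimated value is 15 mL/min/kg with an expected range from 8 mL/min/kg to 28 mL/min/kg in the coming measurement.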

Compound 4, clearance: 16 mL/min/kg
For compound 4 the middle estimate is 1.1-fold (0.03 log units) below the measured one; low and high end bracket the measured number.
By their numbers in this assay, from the lowest: compounds 2, 4, 1 and 3 (each within the scatter of the next).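

In this assay, the step from cyclopropyl to isopropyl on the ring nitrogen gives a 1.3-fold higher number from compound 2 to compound 4 (0.12 log units; within the scatter) and the step from hydrogen to isopropyl gives a 1.4-fold lower number from compound 1 to compound 4 (0.14 log units; within the scatter), so isopropyl does not separate from either of the other two groups at this nitrogen. The exchange of (1-ethylpiperidin-4-yl)methyl for (1-isopropylpiperidin-4-yl)oxy on the aromatic carbon, which alters the link and the group on the nitrogen together, gives a 1.5-fold lower number from compound 3 to compound 4 (0.18 log units; within the scatter) and also stays within the scatter. Within the data shown here, compound 4 thus adds a further nitrogen group and a further two-part exchange at this position, and still no step among the four compounds goes beyond the scatter.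

No accompanying measurement bears on why these clearance numbers lie so close together. The four compounds also leave open how the oxygen link and the nitrogen group each count alone, which a (1-ethylpiperidin-4-yl)oxy group would address, and whether a longer chain or a carboxylic acid on the ring nitrogen would move clearance beyond the scatter.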